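The source may report more compounds than this note shows. Statements on the series, on what has been measured and on what is new or still open speak of the compounds shown alone.

Measured so far in a functional assay on MCF7 cells (Homo sapiens) for inhibition, read by MTT assay, with a stated time of 72 h; on this read-out lower numbers stand for stronger inhibition and higher numbers for weaker inhibition:
- compound 1 (`COc1cc(NC(C)CCCNC(=O)Nc2ccc(F)cc2)c2ncccc2c1`): 26000 nM
- compound 2 (`COc1cc(NC(C)CCCNC(=O)Nc2cccc(O)c2)c2ncccc2c1`): 11000 nM

Compound 2 holds the lower of the two numbers, and compound 1 sits above it. The next compound to read is compound 3 (`COc1cc(NC(C)CCCNC(=O)NNC(=O)Nc2cccc(Cl)c2)c2ncccc2c1`). The change from compound 2 is ((3-chlorophenyl)carbamoyl)amino in place of 3-hydroxyphenyl on an amide-type nitrogen.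

Going by the values given here, only one measured step bears on this. It acts at the same place, exchanging 4-fluorophenyl for 3-hydroxyphenyl, and it is modest (a 2.4-fold lower number from compound 1 to compound 2 (0.37 log units; beyond the scatter)). Among the compounds with values here, that step swaps one phenyl group for another, whereas the entering group here has more heavy atoms and a carbonyl, and no measured compound carries it. The step therefore gives no firm direction, and no shift beyond the scatter is expected in this assay, though the uncertainty is wide. The estimate amounts to an expected 1.1-fold lower number from compound 2 to compound 3 (0.04 log units; within the scatter) in this read-out. For compound 3 the expected value is 10000 nM (estimated range 2000 nM to 45000 nM).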

Compound 3, half-maximal inhibitory concentration: 220 nM
Estimate against measurement, compound 3: 45-fold (1.66 log units) above; the whole stated range lies above it.
By their numbers in this assay, from the lowest: compound 3; then compound 2; then compound 1.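

At this position, on an amide-type nitrogen whose other neighbour is a carbonyl carbon, placing ((3-chlorophenyl)carbamoyl)amino in this assay gives (a 50-fold lower number from compound 2 to compound 3 (1.70 log units; beyond the scatter)) against the 3-hydroxyphenyl group and (a 120-fold lower number from compound 1 to compound 3 (2.07 log units; beyond the scatter)) against the 4-fluorophenyl group. The exchange of one phenyl group for another had shown only a modest move (a 2.4-fold lower number from compound 1 to compound 2 (0.37 log units; beyond the scatter)), so this position can shift the read-out far more than that exchange revealed, and it does so with a larger entering group that keeps a six-membered aromatic ring of carbon only and adds a carbonyl. Nothing available explains the gain.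

The chlorine and the extended carbamoyl-amino link enter together in compound 3, so their separate shares in the gain remain unresolved. On these data alone, how a plain 3-chlorophenyl group on the same nitrogen, or a methyl group in place of the chlorine on the extended group, would read in this assay remains open.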